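A few compounds are considered here, and "the series" means these few. Any claim that something is new, unique, unknown or untested is made for them only; others in the source may bear on it.

Measured compounds in an ADME assay on MDCK cells (Canis lupus familiaris) for cytotoxicity, read by MTT assay, with a stated time of 3 days; a lower number here means that less compound is tolerated, a higher number that more compound is tolerated:
Compound 1 `CC1(C)C[C@H](O)C[C@](C)(CNc2cccc(C(F)(F)F)c2)C1`: 7800 nM
Compound 2 `CC1(C)C[C@H](O)C[C@](C)(CNc2cccc(Oc3ccccc3)c2)C1`: 6000 nM
Compound 3 `CC1(C)C[C@H](O)C[C@](C)(CNc2cccc(C(N)=O)c2)C1`: > 100000 nM, which is a limit of the assay and not a number.

The three share one core and differ only in the group on the aromatic carbon. Compound 1 gives 7800 nM and compound 2 gives 6000 nM in this assay; the step of a 1.3-fold lower number from compound 1 to compound 2 (0.11 log units; within the scatter) lies within the scatter. Compound 3 stands at the limit of > 100000 nM in this assay, at which 1 of the 3 values shown sits, so for compound 3 only a limit is known. The two steps that lead to it, an at least 12-fold higher number from compound 1 to compound 3 (1.10 log units; beyond the scatter) and an at least 16-fold higher number from compound 2 to compound 3 (1.22 log units; beyond the scatter), are both large and both run toward higher numbers.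

Compound 4 `CC1(C)C[C@H](O)C[C@](C)(CNc2cccc(S(C)(=O)=O)c2)C1` carries methylsulfonyl in place of carbamoyl on an aromatic carbon. For the measured compounds named here, no measured step covers methylsulfonyl; the steps that bear on compound 4 are the two into compound 3, and they show only that the carbamoyl compound reaches the limit. The size of the step from carbamoyl to methylsulfonyl is therefore open; a number near the high end, possibly again a limit, is expected. Compound 4 is estimated at 60000 nM (range 15000 nM to 200000 nM), which means the expected step of an at least 1.6-fold lower number from compound 3 to compound 4 (0.22 log units; that floor lies within the scatter).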

Compound 4, half-maximal cytotoxic concentration: > 50000 nM
Compound 4: only a limit was reported (the forecaster's own chance of this, stated with the estimate: 45%); the middle value lies beyond the limit too.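

In this assay methylsulfonyl is a second group, after carbamoyl, that separates clearly from the trifluoromethyl and phenoxy compounds at this place: an at least 6.4-fold higher number from compound 1 to compound 4 (0.80 log units; beyond the scatter), and an at least 8.3-fold higher number from compound 2 to compound 4 (0.92 log units; beyond the scatter). The high numbers at this place are therefore not tied to a hydrogen-bond donor on the group, since carbamoyl carries one and methylsulfonyl carries none. Compound 4 gives > 50000 nM, which is a limit of the assay and not a number, and the step between compound 3 and compound 4 cannot be read: the limit of > 50000 nM in this assay, at which 1 of the 4 values shown sits.

From the compounds shown here alone, how far compound 3 and compound 4 lie past their limits remains open. Also open, going by these compounds, is whether a nitrile, a carboxylic acid or an amine on this aromatic carbon would give a limit too, or a number close to those of compound 1 and compound 2.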